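This account rests on a few compounds, and the source may have more. Where it says the series, first, only, none or still open, it means among the compounds named here.

Measured compounds in a functional assay on HT-29 cells (Homo sapiens) for antiproliferative activity, read by sulforhodamine B assay, with a stated time of 72 h; a lower number here means a stronger inhibitor, a higher number a weaker inhibitor:
- compound 1 `S=C(N/N=C/c1ccc2ccccc2n1)Nc1cccc(Cl)c1`: 48100 nM
- compound 2 `NC(=S)N/N=C/c1cc2ccccc2s1`: 99200 nM
- compound 3 `NC(=S)N/N=C/c1cc2cccnc2s1`: > 100000 nM

Compound 1 stands lowest of the two numbers in this assay; compound 2 sits at a higher number, and the gap between them lies beyond the usual scatter. For compound 3 the entry is a limit of the assay and not a number (the limit of > 100000 nM in this assay, at which 1 of the 3 values shown sits). All three compounds share the thiosemicarbazone chain joined to a fused bicyclic aromatic unit, but the numbers here are high throughout, so the series as a whole is weak in this assay.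

Compound 4 `COc1ccc(NC(=S)N/N=C/c2ccc3ccccc3n2)cc1` is not yet measured. It differs from compound 1 in one place (4-methoxyphenyl in place of 3-chlorophenyl on an amide-type nitrogen). Among the measured compounds shown here, no pair of measured compounds differs in a single place, so no measured step can be set against this change. With the core of compound 1 kept and only the aryl group on the thiocarbonyl nitrogen exchanged, the expected step from compound 1 to compound 4 is small and its direction uncertain, most likely within the scatter: a 1.1-fold higher number from compound 1 to compound 4 (0.06 log units; within the scatter). Compound 4 is therefore expected to give about 55000 nM in this assay, within a range from 20000 nM to 150000 nM, with a real chance that only a limit is reported.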

Compound 4, half-maximal inhibitory concentration: 82300 nM
Compound 4: middle estimate off by 1.5-fold (0.18 log units), on the low side, within the range that was stated.
By their numbers in this assay, from the lowest: compounds 1, 4 and 2 (each within the scatter of the next, the first and the last beyond it). At a limit, above all of these: compound 3.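

In this assay, among the compounds shown here, 4-methoxyphenyl in place of 3-chlorophenyl on the amide-type nitrogen gives the first single-place step: a 1.7-fold higher number from compound 1 to compound 4 (0.23 log units; within the scatter). On this evidence, the aryl group at this position tolerates a change of substituent and of its printed location on the ring without a difference that can be separated from the scatter, even though the entering group carries 1 hydrogen-bond acceptor and the leaving group 0. No measurement shown bears on the cause of this result, and the single step cannot assign any contribution to the chlorine or to the methoxy group.

This step changes the substituent and its ring location together, so 4-chlorophenyl and 3-methoxyphenyl at the same nitrogen would be needed to separate the two contributions. From the compounds shown here alone, it also remains open whether a markedly different group at this nitrogen, such as a dimethylamino-substituted phenyl, a carboxylic acid-bearing phenyl or a longer alkyl chain, would move the number beyond the scatter on the core of compound 1.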